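The compounds below may be only part of what the source reports. "The series", "measured", "known", "first", "only" and "open" are said of these compounds alone.

In an ADME assay on microsomes from liver (Homo sapiens) for metabolic stability, read by LC-MS, with a stated time of 10 min, tested at 0.5 uM (on this read-out lower numbers stand for a less stable compound and higher numbers for a more stable compound), three compounds sharing one core have been measured. Compound 1 `c1ccc2c(c1)CN[C@@H](CN(CCCN1CCNCC1)[C@H]1CCCc3cccnc31)C2` gives 100%. Compound 2 `c1ccc2c(c1)CN[C@@H](CN(CC[C@@H]1CCCNC1)[C@H]1CCCc3cccnc31)C2` gives 75%, and compound 3 `c1ccc2c(c1)CN[C@@H](CN(CCC1CCNCC1)[C@H]1CCCc3cccnc31)C2` gives 66%. The last two lie within the usual scatter of each other, and both stand clearly under compound 1.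

Compound 4 `CC(C)N1CCN(CCCN(C[C@H]2Cc3ccccc3CN2)[C@H]2CCCc3cccnc32)CC1` differs from compound 3 at one place: (4-isopropylpiperazin-1-yl)methyl in place of piperidin-4-yl on a saturated chain carbon, two bonds along the chain from an amine nitrogen. The entering group is the (piperazin-1-yl)methyl of compound 1 with an isopropyl added, as its name, (4-isopropylpiperazin-1-yl)methyl, shows.

The most relevant measurement is a number 34 percentage points lower from compound 1 to compound 3 (beyond the scatter), which is nearly the same exchange run in reverse, without the isopropyl. A similar exchange gives a number 25 percentage points lower from compound 1 to compound 2 (beyond the scatter), pointing the same way. By contrast, a number 9 percentage points lower from compound 2 to compound 3 (within the scatter) shows that the choice between piperidin-3-yl and piperidin-4-yl makes no clear difference here. Going by the values given here, no measured compound carries the isopropyl, so its contribution is unknown, and only part of the large step is expected to return. The expected change is a number 16 percentage points higher from compound 3 to compound 4 (beyond the scatter), a rise that would be modest rather than large. For compound 4 the estimated value is 82%, with an expected range from 60% to 100%.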

Compound 4, percent of the compound remaining: 46%
For compound 4 the middle estimate is 36 percentage points above the measured one, outside the stated range (below it).
By their numbers in this assay, from the lowest: compound 4; then compounds 3 and 2 (each within the scatter of the next); then compound 1.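

In this assay, isopropyl in place of hydrogen on an amine nitrogen in a ring carries a large cost (a number 54 percentage points lower from compound 1 to compound 4 (beyond the scatter)), so the high number of compound 1 does not survive this single addition. The (4-isopropylpiperazin-1-yl)methyl group also stands under both piperidine groups at this position on the saturated chain carbon (a number 20 percentage points lower from compound 3 to compound 4 (beyond the scatter); a number 29 percentage points lower from compound 2 to compound 4 (beyond the scatter)), which reverses the order seen when the piperazine nitrogen carried hydrogen and shows that a piperazine ring alone does not set the read-out here. Nothing measured for these compounds explains why the number falls with this change.

A methyl, ethyl or acetyl group on the same nitrogen would show whether any substituent there lowers the number or whether the fall belongs to isopropyl in particular. Isopropyl on the ring nitrogen of the piperidin-4-yl group of compound 3 would likewise show whether this substituent has a similar effect on a piperidine ring or only on the piperazine ring of compound 1.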